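The source may report more compounds than this note shows. Statements on the series, on what has been measured and on what is new or still open speak of the compounds shown alone.

In a functional assay on MCF7 cells (Homo sapiens) for antiproliferative activity, read by MTT assay, with a stated time of 48 h (on this read-out higher numbers stand for weaker inhibition and lower numbers for stronger inhibition), compound 1 (`CC[C@@H](C)[C@H](NC(=O)c1ccc(Oc2nc3ccccc3nc2NC(C)(C)C)cc1)C(=O)OC`) gives 33400 nM. Compound 2 (`COC(=O)[C@H](CC(C)C)NC(=O)c1ccc(Oc2nc3ccccc3nc2NC(C)(C)C)cc1`) is known only by a limit of this assay, > 50000 nM, and not by a number. Compound 3 (`CC(C)(C)Nc1nc2ccccc2nc1Oc1ccc(C(=O)NCC(=O)O)cc1`) has carboxymethyl in place of 1-(methoxycarbonyl)-3-methylbutyl on an amide-type nitrogen. Going by the values given here, only one measured step bears on this, and only loosely: an at least 1.4-fold higher number from compound 1 to compound 2 (0.17 log units; that floor lies within the scatter). It exchanges sec-butyl for isobutyl on the saturated chain carbon and leaves the ester in place. Among the compounds with values here, no measured step shows what removing the whole group does, so no large change is expected in this assay, and no gain in potency can be derived from compound 1 at 33400 nM. The expected change is a step that the limit leaves unreadable from compound 2 to compound 3, and a further reading at the limit is likely. For compound 3 the estimate is 60000 nM, with an expected range of 25000 nM to 150000 nM.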

Compound 3, half-maximal inhibitory concentration: > 50000 nM
Compound 3: only a limit was reported; the forecaster's own chance of this, stated with the estimate: 70%; the middle value is on the limit's open side.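

Compound 3, with carboxymethyl on the amide-type nitrogen, is known in this assay only by a limit, > 50000 nM. Going by these compounds alone, the one readable comparison is an at least 1.4-fold higher number from compound 1 to compound 3 (0.17 log units; that floor lies within the scatter), so replacing the whole branched ester group with carboxymethyl yielded no number and no measurable gain, while the step between the two limits cannot be read. At this position, neither the 1-(methoxycarbonyl)-3-methylbutyl nor the carboxymethyl group gives a number, and the readings now gather at a single limit: the limit of > 50000 nM in this assay, at which 2 of the 3 values shown sit.

The compounds shown leave open whether the ester or the side chain matters more, since no carboxylic acid keeps the sec-butyl chain of compound 1. As far as these compounds go, it also remains open whether a benzyl group or a longer chain on that saturated carbon would give a readable value in this assay.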